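This account rests on a few compounds, and the source may have more. Where it says the series, first, only, none or still open, it means among the compounds named here.

Compound 1, `O=C(O)Cn1nc(Cc2nc3cc(Cl)c(OCC(F)F)cc3[nH]2)c2ccccc2c1=O`: 15 nM
Compound 2, `O=C(O)Cn1nc(Cc2nc3cc(Cl)c(OC(F)(F)F)cc3[nH]2)c2ccccc2c1=O`: 342 nM
Compound 3, `CCOc1cc2[nH]c(Cc3nn(CC(=O)O)c(=O)c4ccccc34)nc2cc1Cl`: 109 nM

All three share one core and differ only in the group sitting on an oxygen on an aromatic ring. In a functional assay on CHO cells for antagonist activity at sphingosine 1-phosphate receptor 2 (Homo sapiens), read by GTPgammaS binding (on this read-out higher numbers stand for weaker inhibition and lower numbers for stronger inhibition), compound 3 gives the second highest of the three numbers; its nearest neighbour is compound 2, with a 3.1-fold lower number from compound 2 to compound 3 (0.50 log units; beyond the scatter), and compound 1 stands furthest away, with a 7.3-fold higher number from compound 1 to compound 3 (0.86 log units; beyond the scatter). Compound 4, `COc1cc2[nH]c(Cc3nn(CC(=O)O)c(=O)c4ccccc34)nc2cc1Cl`, has not yet been measured. It differs from compound 3 by hydrogen in place of methyl on a saturated chain carbon bound to an oxygen on an aromatic ring.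

Within the data shown here, no measured step removes a carbon from this chain, so the bearing is indirect. The steps that alter the same group were a 23-fold higher number from compound 1 to compound 2 (1.36 log units; beyond the scatter), a 7.3-fold higher number from compound 1 to compound 3 (0.86 log units; beyond the scatter) and a 3.1-fold lower number from compound 2 to compound 3 (0.50 log units; beyond the scatter). Trifluoromethyl in compound 2 gave the highest number, while difluoroethyl in compound 1 gave 15 nM and ethyl in compound 3 gave 109 nM. From this a modest rise in this assay is expected, a 2.3-fold higher number from compound 3 to compound 4 (0.36 log units; beyond the scatter). Compound 4 is therefore estimated at 250 nM, with a range from 80 nM to 800 nM.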

Compound 4, half-maximal inhibitory concentration: 241 nM
Compound 4: the middle estimate sits 1.0-fold (0.02 log units) above what was measured, and the stated range covers the measured number.
By their numbers in this assay, from the lowest: compound 1; then compound 3; then compounds 4 and 2 (each within the scatter of the next).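

Cutting the chain from ethyl to methyl on this oxygen weakens inhibition in this assay (a 2.2-fold higher number from compound 3 to compound 4 (0.34 log units; beyond the scatter)), so one carbon of the chain matters even with no fluorine present. The methyl and trifluoromethyl groups cannot be told apart on this read-out (a 1.4-fold lower number from compound 2 to compound 4 (0.15 log units; within the scatter)), which means that, at this chain length, swapping all three hydrogens for fluorine leaves no visible mark, unlike the gap between ethyl and 2,2-difluoroethyl. The 2,2-difluoroethyl group of compound 1 also keeps a wide lead over the methyl group (a 16-fold higher number from compound 1 to compound 4 (1.21 log units; beyond the scatter)).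

The compounds shown leave open whether a longer chain such as propyl, or a 2,2,2-trifluoroethyl group, on this oxygen would give a lower number than compound 1. Nothing available here explains these differences.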